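The source may hold more compounds than are shown below. What is called first, only, known or untested is meant among the compounds shown, and "the series" means these compounds.

In an assay on isolated protein for inhibition of receptor-type tyrosine-protein phosphatase C (Homo sapiens), read by spectrophotometry (a higher number here means a weaker inhibitor, a lower number a stronger inhibitor), the measured compounds are:
compound 1, `Oc1cc(-c2ccccc2)ccc1C(O)(C(F)(F)F)C(F)(F)F`, > 500000 nM
compound 2, `O=C(COc1ccc2cc(C(O)(C(F)(F)F)C(F)(F)F)c(O)cc2c1)Nc1ccccc1`, > 20000 nM
compound 3, `O=C(COc1ccc2cc(C(O)(C(F)(F)F)C(F)(F)F)c(O)cc2c1)NCc1ccccc1`, > 20000 nM

Compound 2 stands at a limit of this assay, > 20000 nM, and no number is known for it. Compound 3 likewise sits at a limit. Compound 1 too is reported only as a limit. The step that the two limits leave unreadable from compound 2 to compound 3 is therefore not readable. The unmeasured compound 4, `O=C(COc1ccc2cc(C(O)(C(F)(F)F)C(F)(F)F)c(O)cc2c1)NCc1ccc(F)cc1`, differs from compound 2 by 4-fluorobenzyl in place of phenyl on an amide-type nitrogen. Going by the values given here, the single related step bears on it but cannot be sized; the limit of > 20000 nM in this assay, at which 2 of the 3 values shown sit, and the limit of > 500000 nM in this assay, at which 1 of the 3 values shown sits, are all that this assay offers, and both are limits. Compound 4 is expected to stay at or near the same limit, with an estimate of 60000 nM, ranging from 20000 nM to 300000 nM. The step that the limit leaves unreadable from compound 2 to compound 4 is expected to prove unreadable as well.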

Compound 4, half-maximal inhibitory concentration: > 20000 nM
Compound 4 gave a limit, no number; the forecaster's own chance of this, stated with the estimate: 80%; the middle value is on the limit's open side.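

In this assay, going by these compounds alone, compound 4 is reported only as a limit (> 20000 nM) and compound 2 and compound 3 are limits too, so no step among them can be read. The compounds shown leave open whether any group on the amide-type nitrogen would give an actual number in this assay at all.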